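The source may hold more compounds than are shown below. What is called first, only, known or untested is meant among the compounds shown, and "the series" means these compounds.

Measured so far:
Compound 1 `NC(=O)N(O)CC1=Cc2cc(OCc3ccccc3)ccc2OC1` gives 440 nM in an assay (Cavia porcellus) for inhibition of Polyunsaturated fatty acid 5-lipoxygenase (Homo sapiens); a lower number here means a stronger inhibitor, a higher number a weaker inhibitor.
Compound 2 `CCCCCCOc1ccc2c(c1)C=C(CN(O)C(N)=O)CO2` gives 280 nM in this assay.

These two compounds share one core and differ only in the group hanging from the ether oxygen on the aromatic ring. Compound 1 and compound 2 cannot be told apart on these numbers, since the step of a 1.6-fold lower number from compound 1 to compound 2 (0.20 log units; within the scatter) lies within the scatter of repeated measurements.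

Compound 3 `CC1Oc2ccc(OCc3ccccc3)cc2C=C1CN(O)C(N)=O` is the next compound to be tested. It differs from compound 1 by methyl in place of hydrogen on a saturated ring carbon. Among the compounds with values here, the single measured step concerns a different place in the molecule, the group on the aromatic ether oxygen, and it was small. Within the data shown here, no measured step touches the saturated ring carbon next to the ring oxygen, so there is nothing to suggest a change beyond the scatter; the step of no change at the digits printed from compound 1 to compound 3 (within the scatter) is the expectation. Compound 3 is therefore estimated at 440 nM, with a range from 150 nM to 1300 nM.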

Compound 3, half-maximal inhibitory concentration: 220 nM
For compound 3 the middle estimate is 2.0-fold (0.30 log units) above the measured one; the range from low to high includes it.
By their numbers in this assay, from the lowest: compounds 3, 2 and 1 (each within the scatter of the next).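

The saturated ring carbon next to the ring oxygen now has a measured step of its own: methyl in place of hydrogen gives a 2.0-fold lower number from compound 1 to compound 3 (0.30 log units; within the scatter) in this assay and so leaves compound 1 and compound 3 impossible to tell apart on these numbers. The earlier pair spoke only about the group on the aromatic ether oxygen, whereas this result shows that a methyl at this second place in the molecule produces no difference beyond the scatter. No outside measurement bears on this result.

A single methyl says little about what a larger or different group on this carbon would do, such as an ethyl, a phenyl or a carboxylic acid. Going by these compounds, it also remains open whether the same methyl would give a similar step on compound 2.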